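A few compounds are considered here, and "the series" means these few. Any claim that something is new, unique, unknown or untested is made for them only; others in the source may bear on it.

In a functional assay on the whole organism for positive allosteric modulation, with Mus musculus as the target (on this read-out lower numbers stand for an effect already at smaller amounts and higher numbers for an effect only at larger amounts of compound), compounds sharing one core differ in a single group on the aromatic ring. Compound 1 `CCC(=O)N(c1ccc(OC)cc1)C1CCCC1N(C)C` gives 30 mg/kg; 30 mg/kg (2 entries), and compound 2 `CCC(=O)N(c1ccc(C(F)(F)F)cc1)C1CCCC1N(C)C` gives 10 mg/kg. Compound 3 `CCC(=O)N(c1ccc(C(=O)OC)cc1)C1CCCC1N(C)C` reads > 50 mg/kg, which is a limit of the assay and not a number.

Compound 4 `CCC(=O)N(c1ccc(C#N)cc1)C1CCCC1N(C)C`, not yet measured, has cyano in place of the methoxycarbonyl of compound 3, on an aromatic carbon: cyano in place of methoxycarbonyl on an aromatic carbon. Going by the values given here, the one measured step bearing on this change is an at least 5.0-fold higher number from compound 2 to compound 3 (0.69 log units; beyond the scatter), which lies beyond the scatter. Going by these compounds, its true size stays open, since it ends at a limit. Cyano has not been tested here, so the expectation rests on that step being partly undone once methoxycarbonyl leaves, with compound 4 landing in the region of compound 1 at 30 mg/kg; 30 mg/kg (2 entries) and compound 2 at 10 mg/kg. The expected change is an at least 2.5-fold lower number from compound 3 to compound 4 (0.39 log units; beyond the scatter), towards a lower number. For compound 4 the estimate is 20 mg/kg, with an expected range from 7 mg/kg to 50 mg/kg.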

Compound 4, dose for half-maximal effect: 10 mg/kg
Compound 4: middle estimate off by 2.0-fold (0.30 log units), on the high side; the range from low to high includes it.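

In this assay, cyano in place of methoxycarbonyl gives an at least 5.0-fold lower number from compound 3 to compound 4 (0.69 log units; beyond the scatter), so the poor reading of compound 3 does not extend to every replacement of trifluoromethyl at this position. Going by these compounds alone, the second step, no change at the digits printed from compound 2 to compound 4 (within the scatter), adds what the earlier compounds could not show: two different groups at this position, cyano and trifluoromethyl, give readings that cannot be told apart. Compound 3 stands at a limit of the assay and not at a number, so the true size of the first step stays open: the limit of > 50 mg/kg in this assay, at which 1 of the 4 values shown sits.

The compounds shown do not tell which feature of methoxycarbonyl goes with its poor reading, or why cyano and trifluoromethyl read alike. Going by these compounds, how an amine or a carboxylic acid at this position would read also stays open.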